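Swapping Ethoxy for Trifluoromethyl on Compound 1

The source may report more compounds than this note shows. Statements on the series, on what has been measured and on what is new or still open speak of the compounds shown alone.

Measured so far in a functional assay on T-24 cells (Homo sapiens) for antiproliferative activity, read by MTT assay, with a stated time of 48 h; a higher number here means a weaker inhibitor, a lower number a stronger inhibitor:
compound 1, `CCOc1ccc(NC(=O)Nc2cccc(CNc3nccnc3Cl)c2)cc1`: 9080 nM
compound 2, `O=C(Nc1cccc(CNc2nccnc2Cl)c1)Nc1ccc(Cl)cc1Br`: 6650 nM
compound 3, `O=C(Nc1cccc(CNc2nccnc2Cl)c1)Nc1ccc(Cl)c(Cl)c1`: 5210 nM

Compound 1 stands at the highest of these three numbers, but its gaps to the other two are small: a 1.4-fold lower number from compound 1 to compound 2 (0.14 log units; within the scatter) and a 1.7-fold lower number from compound 1 to compound 3 (0.24 log units; within the scatter), both within the scatter. Compound 4, `O=C(Nc1ccc(C(F)(F)F)cc1)Nc1cccc(CNc2nccnc2Cl)c1`, differs from compound 1 by trifluoromethyl in place of ethoxy on an aromatic carbon. The two measured steps that bear on this change replace the same aromatic group attached to the amide-type nitrogen, and both stayed within the scatter. No step beyond the scatter is therefore expected in this assay, with at most a slight lowering of the number. Compound 4 is estimated at 6500 nM, with a range from 3000 nM to 15000 nM. This expectation corresponds to a 1.4-fold lower number from compound 1 to compound 4 (0.15 log units; within the scatter).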

Compound 4, half-maximal inhibitory concentration: 4580 nM
Beside the measured number, compound 4's estimate is 1.4-fold (0.15 log units) above it, and the stated range covers the measured number.
By their numbers in this assay, from the lowest: compounds 4, 3, 2 and 1 (each within the scatter of the next).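

Unlike the earlier steps, which replaced the whole aromatic group, this change keeps the ring and alters only the group para to a large group. In this assay trifluoromethyl in place of ethoxy gives a 2.0-fold lower number from compound 1 to compound 4 (0.30 log units; within the scatter) and so removes the one hydrogen-bond acceptor counted in the leaving group without a step beyond the scatter. Nothing available explains the size of this step.

Going by these compounds, whether an amine, a carboxylic acid or a longer chain at this place would give a step beyond the scatter remains open.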